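The source may hold more compounds than are shown below. What is called first, only, known or untested is meant among the compounds shown, and "the series" means these compounds.

Compound 1 `CN1C[C@H](C(=O)Nc2ccc(C3CC3)cc2)[C@@H](c2ccc(/C=C/C(=O)Nc3ccccc3N)cc2)C1` stands second highest of the three numbers in an in vitro ADME assay on microsomes from liver (Homo sapiens) for pharmacokinetics, read by LC-MS, with a stated time of 10 min, tested at 1 uM (on this read-out lower numbers stand for slow clearance and higher numbers for fast clearance), where compound 1 gives 12 mL/min/kg. Compound 2 `CN1C[C@H](C(=O)Nc2cccc(Cl)c2)[C@@H](c2ccc(/C=C/C(=O)Nc3ccccc3N)cc2)C1` gives 7 mL/min/kg and compound 3 `Cc1cc(NC(=O)[C@H]2CN(C)C[C@@H]2c2ccc(/C=C/C(=O)Nc3ccccc3N)cc2)ccc1F` gives 15 mL/min/kg; the step of a 1.7-fold lower number from compound 1 to compound 2 (0.23 log units; within the scatter) and the step of a 1.3-fold higher number from compound 1 to compound 3 (0.10 log units; within the scatter) both stay within the scatter, while the step of a 2.1-fold higher number from compound 2 to compound 3 (0.33 log units; beyond the scatter) is modest. Compound 4 `CC(C)NC(=O)[C@H]1CN(C)C[C@@H]1c1ccc(/C=C/C(=O)Nc2ccccc2N)cc1` differs from compound 1 in one place: isopropyl in place of 4-cyclopropylphenyl on an amide-type nitrogen. For the measured compounds named here, none of the measured steps covers an exchange of an aryl group for isopropyl; all three only swap one aryl for another on the same amide-type nitrogen, and all stay small. With nothing beyond these to go on, no step beyond the scatter is expected in this assay, so for compound 4 the expected step is no change at the digits printed from compound 1 to compound 4 (within the scatter). Compound 4 is estimated at 12 mL/min/kg, with a range from 6 mL/min/kg to 25 mL/min/kg.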

Compound 4, clearance: 8 mL/min/kg
Compound 4: the middle estimate sits 1.5-fold (0.18 log units) above what was measured; measured number inside the range.
By their numbers in this assay, from the lowest: compounds 2, 4, 1 and 3 (each within the scatter of the next, the first and the last beyond it).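

In this assay, for the compounds shown here, isopropyl is the only non-aryl group on this amide-type nitrogen, and replacing 4-cyclopropylphenyl with it stays within the scatter (a 1.5-fold lower number from compound 1 to compound 4 (0.18 log units; within the scatter)). The comparisons with the other two aryl groups also stay within the scatter (a 1.9-fold lower number from compound 3 to compound 4 (0.27 log units; within the scatter); a 1.1-fold higher number from compound 2 to compound 4 (0.06 log units; within the scatter)), so across these four compounds the open-chain isopropyl reads like the aryl groups, despite having no ring and fewer heavy atoms. Nothing available explains this result. Still open, going by these compounds, is how clearance responds on this nitrogen to a longer chain, a carboxylic acid or an amine.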